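The compounds below may be only part of what the source reports. "The series", "measured", "known", "first", "only" and "open" are said of these compounds alone.

Compound 1 `COc1cccc(SCc2nc3c(c(=O)n(C)c(=O)n3C)n2C)c1` gives 41300 nM in an in vitro assay on cells for inhibition of Amine oxidase [flavin-containing] A (Homo sapiens), read by fluorescence and spectrophotometry, with a stated time of 20 min; a higher number here means a weaker inhibitor, a lower number a stronger inhibitor. Compound 2 `Cn1c(=O)c2c(nc(CSc3cccc(Br)c3)n2C)n(C)c1=O` gives 23800 nM. Compound 3 `CCOc1cccc(SCc2nc3c(c(=O)n(C)c(=O)n3C)n2C)c1` gives 44700 nM.

The three compounds share one core and differ only in the group carried on the phenyl ring bound to the sulfur. Compound 2 holds the lowest of the three numbers in this assay, but the step of a 1.7-fold lower number from compound 1 to compound 2 (0.24 log units; within the scatter) and the step of a 1.9-fold higher number from compound 2 to compound 3 (0.27 log units; within the scatter) both lie within the scatter, as does a 1.1-fold higher number from compound 1 to compound 3 (0.03 log units; within the scatter), so none of the three can be set apart from the others.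

Compound 4 `Cn1c(=O)c2c(nc(CSc3ccc(Cl)cc3)n2C)n(C)c1=O` is the next member: 4-chlorophenyl in place of 3-bromophenyl on a sulfur. For the measured compounds named here, every measured step so far exchanged one group on that same phenyl ring for another, and each of them, a 1.7-fold lower number from compound 1 to compound 2 (0.24 log units; within the scatter) and a 1.9-fold higher number from compound 2 to compound 3 (0.27 log units; within the scatter) alike, stayed within the scatter. The author therefore expects the move to the 4-chlorophenyl group to behave the same way, with a step of a 1.3-fold higher number from compound 2 to compound 4 (0.10 log units; within the scatter) that does not exceed the scatter. For compound 4 the estimated value in this assay is 30000 nM, with a range from 12000 nM to 75000 nM.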

Compound 4, half-maximal inhibitory concentration: 31600 nM
Compound 4: middle estimate off by 1.1-fold (0.02 log units), on the low side, and the stated range covers the measured number.
By their numbers in this assay, from the lowest: compounds 2, 4, 1 and 3 (each within the scatter of the next).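

In this assay, this change alters two things at once, replacing the bromo with a chloro and going from a 3-bromophenyl to a 4-chlorophenyl group on the sulfur, and the result is a 1.3-fold higher number from compound 2 to compound 4 (0.12 log units; within the scatter). Against the 3-methoxyphenyl group the same 4-chlorophenyl group gives a 1.3-fold lower number from compound 1 to compound 4 (0.12 log units; within the scatter), so among these compounds a group named at the 4 position of the phenyl ring reads no differently from those named at the 3 position. No measurement shown gives a reason for this result.

The compounds shown do not separate the effect of the chloro from that of its place on the ring, which a 3-chlorophenyl or 4-bromophenyl group would address. They also leave open whether an amine or a carboxylic acid on the phenyl ring would move the number beyond the scatter.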